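This account rests on a few compounds, and the source may have more. Where it says the series, first, only, none or still open, it means among the compounds named here.

Compound 2 `CC(CC[C@H]1/C(=C/c2ccc(F)cc2)CC[C@H]2C(C)(C)CCC[C@]12C)CC(=O)O` carries a fluoro group on an aromatic carbon of its six-membered ring. In a functional assay on K562 cells (Homo sapiens) for cytotoxicity, read by MTT assay, with a stated time of 24 h (a higher number here means a weaker inhibitor, a lower number a stronger inhibitor), compound 2 gives only a limit of > 200000 nM, not a measured number. Compound 1 `Cc1ccc(/C=C2\CC[C@H]3C(C)(C)CCC[C@]3(C)[C@H]2CCC(C)CC(=O)O)cc1` differs from it by a methyl in place of that fluoro. In this assay compound 1 likewise gives a limit of > 200000 nM. The step that the two limits leave unreadable from compound 1 to compound 2 cannot be read in size or direction because both values sit at the limit of > 200000 nM in this assay, at which 2 of the 2 values shown sit. Compound 3 `CC(CC[C@H]1/C(=C/c2ccc(Cl)cc2)CC[C@H]2C(C)(C)CCC[C@]12C)CC(=O)O` is the next member of the series: chloro in place of fluoro on an aromatic carbon. Among the measured compounds shown here, the only measured step on the same aromatic carbon, a step that the two limits leave unreadable from compound 1 to compound 2, offers no readable size, so no change beyond the scatter can be predicted from it. Compound 3 is therefore expected to remain at the limit, with an estimated 200000 nM and a range from 100000 nM to 400000 nM. The expected step is a number no higher from compound 2 to compound 3 (the limit leaves the size open).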

Compound 3, half-maximal inhibitory concentration: > 200000 nM
Compound 3 was reported as a limit; the forecaster's own chance of this, stated with the estimate: 80%; the middle value sits exactly at the limit.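

Among the compounds shown here, no step among compound 1, compound 2 and compound 3 can be read in size or direction, because each of their values is a limit and not a number: the limit of > 200000 nM in this assay, at which 3 of the 3 values shown sit. The compounds shown leave open whether methyl, fluoro and chloro differ at all in this assay.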